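Repositioning a fluorine: from compound 3 to compound 4

The source may report more compounds than this note shows. Statements on the series, on what has been measured and on what is new or still open speak of the compounds shown alone.

The measured compounds and their values in a functional assay on A-375 cells (Homo sapiens) for antiproliferative activity, read by CCK-8 assay, with a stated time of 72 h, tested at 2 uM; on this read-out lower numbers stand for a weaker effect and higher numbers for a stronger effect at the one concentration tested:
compound 1, `Nc1ccccc1NC(=O)c1ccc(CSC(=S)N2CCN(Cc3ccccn3)CC2)cc1`: 20.7%
compound 2, `Nc1ccccc1NC(=O)c1ccc(CSC(=S)N2CCN(C3CCCCC3)CC2)cc1`: 31.7%
compound 3, `Nc1ccccc1NC(=O)c1ccc(CSC(=S)N2CCN(c3ccc(F)cc3)CC2)cc1`: 20.9%

Three compounds share one core and differ only in the group on an amine nitrogen in a ring. Compound 3 stands second highest of the three numbers in this assay; its value and that of compound 1 lie within the scatter of each other, as a number 0.2 percentage points higher from compound 1 to compound 3 (within the scatter) shows, while compound 2 sits clearly above it, as a number 10.8 percentage points lower from compound 2 to compound 3 (beyond the scatter) shows. The rise a number 11 percentage points higher from compound 1 to compound 2 (beyond the scatter) is the other step beyond the scatter.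

Compound 4, `Nc1ccccc1NC(=O)c1ccc(CSC(=S)N2CCN(c3ccccc3F)CC2)cc1`, has not been measured. The change is 2-fluorophenyl in place of 4-fluorophenyl on an amine nitrogen in a ring. Within the data shown here, none of the measured steps moves the fluorine within an aromatic ring; they exchange whole groups, so they bear on this step only loosely. With nothing pointing to a shift, compound 4 is expected to stay near compound 3, and the step of a number 1.1 percentage points higher from compound 3 to compound 4 (within the scatter) is expected to lie within the scatter. Compound 4 is therefore estimated at 22%, with a range from 10% to 36%.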

Compound 4, a percentage reported as inhibition, at one concentration (the size of the read-out at that concentration, not a potency): 18.7%
The estimate for compound 4 lay 3.3 percentage points above the measured number; low and high end bracket the measured number.
By their numbers in this assay, from the lowest: compounds 4, 1 and 3 (each within the scatter of the next); then compound 2.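

In this assay, the shift of the fluorine within the aromatic ring, 2-fluorophenyl in place of 4-fluorophenyl on the amine nitrogen, comes to a number 2.2 percentage points lower from compound 3 to compound 4 (within the scatter) and so does not tell the two placings apart. The 2-fluorophenyl group also stands level with the (pyridin-2-yl)methyl group, at a number 2 percentage points lower from compound 1 to compound 4 (within the scatter) in this comparison, while the exchange for cyclohexyl remains a real one, at a number 13 percentage points lower from compound 2 to compound 4 (beyond the scatter) and in line with compound 2 standing clear of the other three. Nothing available offers a reason for these numbers.

Still open, on these data alone, is whether a 4-methoxyphenyl or 2-chlorophenyl group on the same nitrogen would separate from the two fluorophenyl compounds. As far as these compounds go, it is also open whether an open-chain group such as n-hexyl would reach the level that compound 2 holds with its cyclohexyl group.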